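The compounds below may be only part of what the source reports. "The series", "measured", "known", "first", "only" and "open" are said of these compounds alone.

Compound 3, with the structure `Clc1ccc(-c2cc(-c3cccs3)nc(-c3ccccc3Cl)c2)o1`, was tested in a functional assay on K562 cells (Homo sapiens) for cytotoxicity, in the presence of a further agent that is not named here (on this read-out higher numbers stand for weaker inhibition and lower numbers for stronger inhibition), where compound 3 gave 17200 nM. Among the three compounds measured so far this is the lowest number, but only within the scatter: compound 1, `Clc1cccc(-c2cc(-c3ccc(Cl)o3)cc(-c3cccs3)n2)c1`, gave 19800 nM, and compound 2, `Clc1ccc(-c2cc(-c3cccnc3)nc(-c3ccsc3)c2)o1`, gave 21700 nM. The only one-place step among these is a 1.2-fold lower number from compound 1 to compound 3 (0.06 log units; within the scatter), which moved nothing beyond the scatter.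

Compound 4, `Clc1ccc(-c2cc(-c3cccnc3)nc(-c3cccs3)c2)o1`, differs from compound 3 by pyridin-3-yl in place of 2-chlorophenyl on an aromatic carbon, on an aromatic carbon of the shared core. Among the compounds with values here, no measured step covers this exchange directly; the single one-place step concerns the position of chlorine on a chlorophenyl group rather than replacement of that group. Compound 2 does carry a pyridin-3-yl group and its value of 21700 nM sits within the scatter of compound 3, though it differs from compound 4 in a second place, so it can only suggest, not fix, the outcome. Compound 4 is therefore expected to show a 1.2-fold higher number from compound 3 to compound 4 (0.07 log units; within the scatter), a step not beyond the scatter, with an estimated value of 20000 nM in this assay, in the range 10000 nM to 42000 nM.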

Compound 4, half-maximal inhibitory concentration: 22300 nM
Compound 4: the middle estimate sits 1.1-fold (0.05 log units) below what was measured; the measured number falls inside the stated range.
By their numbers in this assay, from the lowest: compounds 3, 1, 2 and 4 (each within the scatter of the next).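

In this assay, a pyridin-3-yl group next to the ring nitrogen gave a number within the scatter of both chlorophenyl groups it replaced, 2-chlorophenyl (a 1.3-fold higher number from compound 3 to compound 4 (0.11 log units; within the scatter)) and 3-chlorophenyl (a 1.1-fold higher number from compound 1 to compound 4 (0.05 log units; within the scatter)), so neither the carbon-only ring nor its chlorine shows any effect on the number at this place. Within the data shown here, the same holds for the attachment of the thiophene, which the earlier compounds could not show: thiophen-2-yl in place of thiophen-3-yl also stayed within the scatter (a 1.0-fold higher number from compound 2 to compound 4 (0.01 log units; within the scatter)). Nothing available bears on why these exchanges leave the number in place.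

The compounds shown carry only aromatic rings at this place, so what an amine or a carboxylic acid there would do stays open. Also open, as far as these compounds go, is any effect of exchanging the 5-chlorofuran-2-yl group, which all four compounds share.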